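From phenyl to 2-fluorophenyl: an expected small step

The source may report more compounds than this note shows. Statements on the series, on what has been measured and on what is new or still open speak of the compounds shown alone.

Measured so far in a physicochemical assay for lipophilicity; on this read-out lower numbers stand for lower lipophilicity and higher numbers for higher lipophilicity:
Compound 1 `Cc1ccc(C2=NO[C@]3(C2)C(=O)O[C@@H]2[C@H]3CC[C@H](C)[C@]3(O)C=CC(=O)[C@@]23C)cc1`: 1.86
Compound 2 `C[C@H]1CC[C@@H]2[C@@H](OC(=O)[C@]23CC(c2ccccc2)N(c2ccccc2)O3)[C@]2(C)C(=O)C=C[C@@]12O`: 3.19

Among the compounds with values here, of these two numbers, the one for compound 2 is the higher, and compound 1 lies below it by a gap beyond the usual scatter of repeated measurements. These two compounds differ in more than one place, so their gap says nothing about any single change.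

Compound 3 `C[C@H]1CC[C@@H]2[C@@H](OC(=O)[C@]23CC(c2ccccc2F)N(c2ccccc2)O3)[C@]2(C)C(=O)C=C[C@@]12O` differs from compound 2 in one place: fluoro in place of hydrogen on an aromatic carbon. In words, this is fluoro in place of hydrogen on an aromatic carbon, ortho to a large group, which turns phenyl to 2-fluorophenyl. Within the data shown here, no pair of measured compounds shows this change, so the data give no direct guide to its size. The rest of the structure stays as it is, so only a modest movement in this assay seems likely. The expected step of a number 0.16 log units higher from compound 2 to compound 3 (within the scatter) is small and upward, and it may well stay within the scatter. The starting point is compound 2, at 3.19. For compound 3 the estimated value is 3.35, with an expected range from 2.95 to 3.75.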

Compound 3, partition coefficient: 3.35
Compound 3: middle estimate and measured number agree at the digits printed, within the range that was stated.
By their numbers in this assay, from the lowest: compound 1; then compounds 2 and 3 (each within the scatter of the next).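

In this assay, within the data shown here, fluoro in place of hydrogen on an aromatic carbon, ortho to a large group, gives a number 0.16 log units higher from compound 2 to compound 3 (within the scatter) and this is the first reading of any single change in the set, since compound 1 and compound 2 differ in more than one place. On this one pair, the swap of a hydrogen atom for a single fluorine atom at this position leaves the two numbers indistinguishable on this read-out, so the position takes this fluoro without a change that the measurement can resolve. Nothing available here bears on what lies behind this result.

Going by these compounds, one pair covers one group at one place, so it remains open whether chloro, methoxy, an amine or a carboxylic acid at this same aromatic carbon would give a step beyond the scatter. On these data alone, it also remains open whether fluoro in place of hydrogen gives a similar step on other carbons of this ring, or on the second aromatic ring of compound 2 .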